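Phenyl thioether in place of bromophenyl ether on the chain

This account rests on a few compounds, and the source may have more. Where it says the series, first, only, none or still open, it means among the compounds named here.

Measured compounds:
Compound 1 `COc1cc(C(C)=O)ccc1OCCCCCN1CCC(C(c2ccc(F)cc2)c2ccc(F)cc2)CC1` gives 3.16 nM in a functional assay (aorta) with Oryctolagus cuniculus as the target; a higher number here means weaker binding, a lower number tighter binding.
Compound 2 `COC(=O)c1ccc(OCCCN2CCC(C(c3ccc(F)cc3)c3ccc(F)cc3)CC2)c(OC)c1` gives 1.26 nM in this assay.
Compound 3 `Fc1ccc(C(c2ccc(F)cc2)C2CCN(CCCOc3ccc(Br)cc3)CC2)cc1` gives 1.59 nM in this assay.

All three compounds share the same core and differ only in the aryl group at the far end of the chain. Compound 3 sits among them: its nearest neighbour is compound 2 and its furthest is compound 1, and both gaps are within the usual scatter, so the three numbers cannot be ranked.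

Compound 4 `Fc1ccc(C(c2ccc(F)cc2)C2CCN(CCCSc3ccccc3)CC2)cc1` is not yet measured. It differs from compound 3 by phenylsulfanyl in place of 4-bromophenoxy on a saturated chain carbon, three bonds along the chain from an amine nitrogen in a ring.

Within the data shown here, the one step that bears on this is the aryl swap on the same oxygen, which gave a 1.3-fold higher number from compound 2 to compound 3 (0.10 log units; within the scatter). That step shows the aryl group can be changed with little effect. The replacement of oxygen by sulfur has no precedent here, so nothing shown speaks for or against it.

Compound 4 is therefore expected to give about 2.5 nM, with a range from 0.8 nM to 8 nM; the step from compound 3 is estimated as a 1.6-fold higher number from compound 3 to compound 4 (0.20 log units; within the scatter).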

Compound 4, dissociation constant: 3.16 nM
Estimate against measurement, compound 4: 1.3-fold (0.10 log units) below, within the range that was stated.
By their numbers in this assay, from the lowest: compounds 2, 3, 1 and 4 (each within the scatter of the next, the first and the last beyond it).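

Swapping 4-bromophenoxy for phenylsulfanyl gives a 2.0-fold higher number from compound 3 to compound 4 (0.30 log units; within the scatter) in this assay. Among these compounds, the earlier compounds all kept an oxygen on the chain, so this is the first sign that a sulfur can stand in that place, and that an aryl group without bromine can sit there, with no change beyond the scatter. Nothing available explains this result.

The step changes the oxygen and removes the bromine at once, so the compounds shown cannot tell whether either change matters alone or whether the two offset each other; phenoxy or 4-bromophenylsulfanyl on the same chain would separate them. They also leave open how a sulfone, or an amine nitrogen in place of the sulfur, would read at this position.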